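Swapping the aryl group on the sulfur linker

The source may report more compounds than this note shows. Statements on the series, on what has been measured and on what is new or still open speak of the compounds shown alone.

Measured compounds in a functional assay on SF-268 cells (Homo sapiens) for inhibition, read by sulforhodamine B assay, with a stated time of 48 h; a lower number here means a stronger inhibitor of growth, a higher number a weaker inhibitor of growth:
compound 1 `Nc1cc(N)c2nc(-c3ccccc3)c(Oc3ccc(Cl)c(Cl)c3)nc2c1` gives 52500 nM
compound 2 `Nc1cc(N)c2nc(-c3ccccc3)c(NCc3ccc(F)cc3)nc2c1` gives 7590 nM
compound 3 `Nc1cc(N)c2nc(-c3ccccc3)c(Sc3ccc(Cl)c(Cl)c3)nc2c1` gives 51300 nM

Compound 3 holds the second highest of the three numbers in this assay. Its value and that of compound 1 sit together, since a 1.0-fold lower number from compound 1 to compound 3 (0.01 log units; within the scatter) lies within the scatter, whereas compound 2 stands apart, as a 6.8-fold higher number from compound 2 to compound 3 (0.83 log units; beyond the scatter) shows. Compound 4 `Nc1cc(N)c2nc(-c3ccccc3)c(Sc3ccc(F)cc3)nc2c1` differs from compound 3 by 4-fluorophenyl in place of 3,4-dichlorophenyl on a sulfur. Within the data shown here, no measured step alters the aryl group on the sulfur alone; the one step that brings in a fluorine-bearing ring, a 6.9-fold lower number from compound 1 to compound 2 (0.84 log units; beyond the scatter), also exchanges the linker, so it bears only loosely on this change. For compound 4 a small step toward a lower number is expected, a 1.7-fold lower number from compound 3 to compound 4 (0.23 log units; within the scatter). Compound 4 is estimated at 30000 nM, within a range from 10000 nM to 80000 nM.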

Compound 4, concentration for total growth inhibition: 38900 nM
For compound 4 the middle estimate is 1.3-fold (0.11 log units) below the measured one; the measured number falls inside the stated range.
By their numbers in this assay, from the lowest: compound 2; then compounds 4, 3 and 1 (each within the scatter of the next).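

In this assay, among these compounds, the aryl group on the sulfur changes alone for the first time, and 4-fluorophenyl in place of 3,4-dichlorophenyl leaves the number within the scatter (a 1.3-fold lower number from compound 3 to compound 4 (0.12 log units; within the scatter)). Compound 4 also stays within the scatter of the oxygen-linked compound (a 1.3-fold lower number from compound 1 to compound 4 (0.13 log units; within the scatter)), yet remains apart from the (4-fluorobenzyl)amino compound (a 5.1-fold higher number from compound 2 to compound 4 (0.71 log units; beyond the scatter)), so a 4-fluorophenyl group on sulfur does not reproduce the number of compound 2. Nothing available explains these readings. As far as these compounds go, whether a benzyl group on the sulfur, or an amine or a carboxylic acid on the aryl ring, would move the number remains open.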